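Bromo to Cyano: Expected Exposure of Compound 4

The source may report more compounds than this note shows. Statements on the series, on what has been measured and on what is new or still open speak of the compounds shown alone.

Three compounds have been measured in an ADME assay on the whole organism (Mus musculus, strain CD-1) for pharmacokinetics, at a dose of 10 mg/kg by the oral route; on this read-out higher numbers stand for higher exposure at the dose given and lower numbers for lower exposure:

Compound 1 `COc1cc([C@](O)(CCN(C)C)[C@@H](c2cc3cc(Br)ccc3nc2OC)c2ccnc(OC)c2OC)cc(OC(F)F)n1`: 9800 ng.h/mL
Compound 2 `COc1cc([C@](O)(CCN(C)C)[C@@H](c2cc3cc(C#N)ccc3nc2OC)c2ccnc(OC)c2OC)cc(OC(F)F)n1`: 3000 ng.h/mL
Compound 3 `COc1cc([C@](O)(CCN(C)C)[C@@H](c2cc3cc(Br)ccc3nc2OC)c2cccc(OC)c2F)cc(SC)n1`: 4600 ng.h/mL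

Compound 2 differs from compound 1 by cyano in place of bromo on an aromatic carbon. That change made a 3.3-fold lower number from compound 1 to compound 2 (0.51 log units; beyond the scatter). Compound 3 stands on a different core from compound 1; the difference between the two cores is not broken down here.

Compound 4 `COc1cc([C@](O)(CCN(C)C)[C@@H](c2cc3cc(C#N)ccc3nc2OC)c2cccc(OC)c2F)cc(SC)n1` differs from compound 3 by cyano in place of bromo on an aromatic carbon. The place of the change matches the earlier one word for word, so it is the same change on the core of compound 3.

The expected step is a 3.3-fold lower number from compound 3 to compound 4 (0.52 log units; beyond the scatter), set beside the earlier one. This expectation rests on the shared change having made a 3.3-fold lower number from compound 1 to compound 2 (0.51 log units; beyond the scatter), and on compound 3 starting from 4600 ng.h/mL.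

Compound 4 is therefore expected to give 1400 ng.h/mL, with an estimated range from 600 ng.h/mL to 3500 ng.h/mL.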

Compound 4, area under the concentration-time curve: 1100 ng.h/mL
Estimate against measurement, compound 4: 1.3-fold (0.10 log units) above; the measured number falls inside the stated range.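

In this assay, cyano in place of bromo on an aromatic carbon of the core of compound 3 gave a 4.2-fold lower number from compound 3 to compound 4 (0.62 log units; beyond the scatter). Set beside the earlier step, the change carried from one core to the other with much the same size: the same change on two cores in this assay, a 3.3-fold lower number (0.51 log units; beyond the scatter) from compound 1 to compound 2 and a 4.2-fold lower number (0.62 log units; beyond the scatter) from compound 3 to compound 4, 1.3-fold (0.11 log units) apart, within the scatter of two such steps. For the compounds shown here, this agreement rests on only two cores and one pair of groups, so it does not show that the step would hold on a further core, nor does it explain why the number falls.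

The compounds shown leave open how a chloro group or an amide at the same place would compare with bromo and cyano. They also leave open whether any such group would keep the higher numbers seen with bromo on these two cores.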